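The source may report more compounds than this note shows. Statements on the series, on what has been measured and on what is new or still open speak of the compounds shown alone.

Values in an in vitro ADME assay on microsomes from liver (Homo sapiens) for metabolic stability, using NADPH; a higher number here means faster removal of the compound, a lower number slower removal:
- compound 1 `CC(C)(O)CCNC(=O)c1cc2cc(C#N)ccc2n1Cc1cccc(OC(F)(F)F)c1`: 9 mL.min-1.g-1
- compound 2 `CC(O)CCNC(=O)c1cc2cc(C#N)ccc2n1Cc1cccc(OC(F)(F)F)c1`: 113 mL.min-1.g-1
- compound 3 `N#Cc1ccc2c(c1)cc(C(=O)NCCC(O)(C(F)(F)F)C(F)(F)F)n2Cc1cccc(OC(F)(F)F)c1`: 20 mL.min-1.g-1

Compound 3 stands second highest of the three, with a 2.2-fold higher number from compound 1 to compound 3 (0.35 log units; beyond the scatter) and a 5.7-fold lower number from compound 2 to compound 3 (0.75 log units; beyond the scatter). Compound 4 `N#Cc1ccc2c(c1)cc(C(=O)NCCC1(O)CCC1)n2Cc1cccc(OC(F)(F)F)c1` follows, and the change is 1-hydroxycyclobutyl in place of 2,2,2-trifluoro-1-hydroxy-1-(trifluoromethyl)ethyl on a saturated chain carbon, two bonds along the chain from an amide-type nitrogen. Among the compounds with values here, no measured step makes this exact exchange. The closest guide is a 2.2-fold higher number from compound 1 to compound 3 (0.35 log units; beyond the scatter), a modest exchange of the same group for 1-hydroxy-1-methylethyl. The large 13-fold higher number from compound 1 to compound 2 (1.10 log units; beyond the scatter) puts hydrogen in place of methyl, and compound 4 has no such hydrogen on its hydroxyl carbon. No direction can be argued, so the expected step, no change at the digits printed from compound 3 to compound 4 (within the scatter), stays within the scatter. The estimate for compound 4 is 20 mL.min-1.g-1, with an expected range of 8 mL.min-1.g-1 to 60 mL.min-1.g-1.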

Compound 4, intrinsic clearance in microsomes: 78 mL.min-1.g-1
Estimate against measurement, compound 4: 3.9-fold (0.59 log units) below; the measured number lies above the stated range.
By their numbers in this assay, from the lowest: compound 1; then compound 3; then compounds 4 and 2 (each within the scatter of the next).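

In this assay a hydroxyl carbon without hydrogen does not by itself give a low number, as an 8.7-fold higher number from compound 1 to compound 4 (0.94 log units; beyond the scatter) shows for 1-hydroxycyclobutyl in place of 1-hydroxy-1-methylethyl. The ring also gives a 3.9-fold higher number from compound 3 to compound 4 (0.59 log units; beyond the scatter) against 2,2,2-trifluoro-1-hydroxy-1-(trifluoromethyl)ethyl, whereas a 1.4-fold lower number from compound 2 to compound 4 (0.16 log units; within the scatter) sets it level with 1-hydroxyethyl at this position. Nothing measured here accounts for these steps. Still open, as far as these compounds go, is whether 1-hydroxycyclopentyl, or an amine in place of the hydroxyl, would stay with compound 4 or fall with compound 1.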